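Replacing the fluoromethoxyphenyl group of compound 2

The compounds below may be only part of what the source reports. "The series", "measured", "known", "first", "only" and "open" are said of these compounds alone.

Of the compounds shown here, three have been measured in an ADME assay (Rattus norvegicus, strain Han-wistar) for pharmacokinetics, at a dose of 1.5 umol/kg by the intravenous route; on this read-out higher numbers stand for wider distribution into tissues and lower numbers for narrower distribution. Compound 2 (`COc1cc(F)ccc1-c1ccnc2[nH]c(C3CCN(CC(=O)N(C)C)CC3)cc12`) gives 2.3 L/kg. Compound 1 (`CNC(=O)CN1CCC(c2cc3c(-c4ccc(=O)n(C(C)C)c4)ccnc3[nH]2)CC1`) gives 2.6 L/kg, within the scatter of compound 2. Compound 3 (`COc1cc(C(=O)N2CCCC2)ccc1-c1ccnc2[nH]c(C3CCOCC3)cc12`) gives 0.8 L/kg, and compound 2 stands above it by a gap beyond the scatter. Compound 2 therefore belongs at the upper end of this small set, level with compound 1.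

Compound 4 (`CC(C)n1cc(-c2ccnc3[nH]c(C4CCN(CC(=O)N(C)C)CC4)cc23)cnc1=O`) keeps the piperidine side chain of compound 2 and loses the 4-fluoro-2-methoxyphenyl group. The change is a group of 10 heavy atoms (7 carbon, 2 nitrogen, 1 oxygen; one six-membered aromatic ring with 2 hetero atoms) in place of a group of 9 heavy atoms (7 carbon, 1 oxygen, 1 fluorine; one six-membered aromatic ring of carbon only), on an aromatic carbon, opposite the ring nitrogen of the shared core.

Within the data shown here, no two measured compounds differ in one place only, so no direct measure of such a swap exists. The closest guide is compound 1, which carries a similar isopropyl-bearing ring and gives 2.6 L/kg in this assay. Its side chain differs slightly from that of compound 4. Compound 4 has the same side chain as compound 2, which gives 2.3 L/kg. Little movement beyond the scatter is therefore expected, with a slight downward lean at most. The expected change is a 1.2-fold lower number from compound 2 to compound 4 (0.06 log units; within the scatter). Compound 4 is estimated at 2 L/kg, with an expected range of 1.1 L/kg to 3.7 L/kg.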

Compound 4, volume of distribution: 2.9 L/kg
Estimate against measurement, compound 4: 1.5-fold (0.16 log units) below, within the range that was stated.
By their numbers in this assay, from the lowest: compound 3; then compounds 2, 1 and 4 (each within the scatter of the next).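

In this assay, the position opposite the ring nitrogen now has its first direct reading, with the piperidine side chain held constant: a 1.3-fold higher number from compound 2 to compound 4 (0.10 log units; within the scatter). This read-out therefore does not separate the 4-fluoro-2-methoxyphenyl group from the entering six-membered aromatic ring with 2 hetero atoms, so neither the fluorine, the methoxy group nor a ring of carbon only is needed at this position for a value at the level of compound 2. Nothing measured here offers an explanation for this outcome.

As far as these compounds go, this is a single step, taken on one side chain, so it remains open whether the same swap would read alike if a carboxylic acid or a primary amine replaced the side chain carried by compound 2 and compound 4. From the compounds shown here alone, it also remains open whether this position would stay as undiscriminating with a non-aromatic group such as morpholine or a short alkyl chain in place of the aromatic rings compared here.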